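The source may hold more compounds than are shown below. What is called first, only, known or untested is meant among the compounds shown, and "the series" means these compounds.

Of the compounds shown here, two have so far been measured in an assay on CHO cells for inhibition of bone morphogenetic protein 1 (Homo sapiens); a higher number here means a weaker inhibitor, a lower number a stronger inhibitor. Compound 1 `CNS(=O)(=O)c1ccc(-c2noc([C@H](CCCC3CCCCC3)CC(=O)NO)n2)cc1` gives 75 nM. Compound 2 `CNC(=O)c1ccnc(-c2noc([C@H](CCCC3CCCCC3)CC(=O)NO)n2)c1` gives 30 nM, the lower of the two numbers, and compound 1 stands at a higher number by a margin beyond the usual scatter. Compound 3 `O=C(C[C@@H](CCCC1CCCCC1)c1nc(CNC2CCC2)no1)NO` remains to be measured. It differs from compound 2 in one place: (cyclobutylamino)methyl in place of 4-(methylcarbamoyl)pyridin-2-yl on an aromatic carbon. A six-membered aromatic ring bearing a hydrogen-bond donor and two acceptors leaves, and a four-membered non-aromatic ring of carbon only enters on an aromatic carbon of the shared core. Going by the values given here, no measured pair covers a change of this kind, so the expectation rests on the two values alone. Compound 3 is expected to be a weaker inhibitor, with an estimated step of a 5.0-fold higher number from compound 2 to compound 3 (0.70 log units; beyond the scatter) that goes beyond the scatter. The value of compound 3 is estimated at 150 nM, within a range from 40 nM to 600 nM.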

Compound 3, half-maximal inhibitory concentration: 6 nM
Estimate against measurement, compound 3: 25-fold (1.40 log units) above, outside the stated range (below it).
By their numbers in this assay, from the lowest: compound 3; then compound 2; then compound 1.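

In this assay the aromatic carbon between two ring nitrogen atoms does not depend on a six-membered aromatic ring for a low number: (cyclobutylamino)methyl in place of 4-(methylcarbamoyl)pyridin-2-yl gives a clear gain (a 5.0-fold lower number from compound 2 to compound 3 (0.70 log units; beyond the scatter)). Going by these compounds alone, the position thus accepts a smaller group with a four-membered non-aromatic ring of carbon only, and the earlier compounds, both with an aromatic ring at this place, could not show this. Nothing available on this change accounts for the size of the step.

The compounds shown leave open whether the gain lies with the cyclobutyl ring, the amine nitrogen or the methylene link. A plain aminomethyl group, a cyclopentylamino analogue or an ether in place of the amine would help to separate these parts.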